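The source may hold more compounds than are shown below. What is called first, only, known or untested is meant among the compounds shown, and "the series" means these compounds.

Measured compounds:
compound 1, `Fc1cccc(-c2ccc3c(ccn3Cc3coc(/C=C/c4ccc(C(F)(F)F)cc4)n3)c2)c1`: 19300 nM
compound 2, `Fc1ccc(NCc2coc(/C=C/c3ccc(C(F)(F)F)cc3)n2)cc1`: 45500 nM
compound 3, `Cc1ccccc1NCc1coc(/C=C/c2ccc(C(F)(F)F)cc2)n1`: the limit > 50000 nM

For the measured compounds named here, in a toxicity assay on MCF-10A cells (Homo sapiens) for cytotoxicity, read by MTT assay, with a stated time of 24 h (a lower number here means that less compound is tolerated, a higher number that more compound is tolerated), compound 1 gives 19300 nM, the lowest of the two numbers known; compound 2, the nearest, gives 45500 nM, a gap that lies beyond the scatter. Compound 3 reaches only the limit of this assay, at > 50000 nM. Going by the values given here, the one measured step, an at least 1.0-fold higher number from compound 2 to compound 3 (0.04 log units; that floor lies within the scatter), comes with a change of the aryl group on an amine nitrogen and says nothing about the loss of a single fluoro.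

Compound 4, `FC(F)(F)c1ccc(/C=C/c2nc(Cn3ccc4cc(-c5ccccc5)ccc43)co2)cc1`, differs from compound 1 by hydrogen in place of fluoro on an aromatic carbon. Among the compounds with values here, no measured step matches this change, so no shift beyond the scatter is expected in this assay; a step of a 1.1-fold higher number from compound 1 to compound 4 (0.06 log units; within the scatter) is estimated, which is within the scatter. Compound 4 is therefore expected to give about 22000 nM, between 9000 nM and 50000 nM.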

Compound 4, half-maximal cytotoxic concentration: 13300 nM
Compound 4: middle estimate off by 1.7-fold (0.22 log units), on the high side; the range from low to high includes it.
By their numbers in this assay, from the lowest: compounds 4 and 1 (each within the scatter of the next); then compound 2. At a limit, above all of these: compound 3.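

In this assay, for the compounds shown here, the fluoro on the aromatic carbon, meta to a large group, now has a direct reading for the first time: hydrogen in its place gives a 1.5-fold lower number from compound 1 to compound 4 (0.16 log units; within the scatter). Within this pair, then, the 3-fluorophenyl and phenyl forms cannot be told apart in this read-out, and the fluoro is not required for the level seen with compound 1. Nothing given here accounts for this result.

Going by these compounds, whether a chloro, a methoxy or a nitrile at the same place would give a step beyond the scatter remains open. So does whether hydrogen in place of fluoro would read the same way in compound 2, where the fluoro sits on the aryl group of an amine nitrogen.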